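The source may hold more compounds than are shown below. What is called first, only, known or untested is meant among the compounds shown, and "the series" means these compounds.

In an assay on isolated protein (Mus musculus) for inhibition of IL15-IL15 receptor (Homo sapiens), read by resazurin assay, with stated times of 30 min and 2.5 days (on this read-out lower numbers stand for stronger inhibition and higher numbers for weaker inhibition), compound 1 `Cn1c(Cc2nn(C)c(=O)c3ccccc23)nnc1SCCCCCCCC(=O)Nc1ccc(I)cc1` gives 1300 nM, and compound 3 `Cn1c(Cc2nn(C)c(=O)c3ccccc23)nnc1SCCCCCCCC(=O)Nc1ccc(Br)cc1Br` gives 1500 nM. These two share everything except the aryl group on the amide nitrogen, and a 1.2-fold higher number from compound 1 to compound 3 (0.06 log units; within the scatter), so on this read-out the two aryl groups are indistinguishable. Compound 2 `CC(C)COc1ccc(NC(=O)CSc2nnc(Cc3nn(C)c(=O)c4ccccc34)n2C)cc1` gives 30000 nM, the highest of the three numbers and therefore the weakest inhibition measured so far. For the measured compounds named here, compound 2 differs from compound 3 in more than one place, so no single step connects them, and only their two values can be compared.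

Compound 4 `Cn1c(Cc2nn(C)c(=O)c3ccccc23)nnc1SCC(=O)Nc1ccc(Br)cc1Br` has not yet been measured. It differs from compound 2 in one place: 2,4-dibromophenyl in place of 4-(isobutoxy)phenyl on an amide-type nitrogen. Going by the values given here, the one measured step that bears on this change, from compound 1 to compound 3, shows that swapping one halogenated aryl group for the 2,4-dibromophenyl group stayed within the scatter. The present change is larger, since the leaving group also carries an ether oxygen. The expectation is therefore that compound 4 changes little or moves toward the lower numbers of compound 1 and compound 3, with the estimated step being a 2.5-fold lower number from compound 2 to compound 4 (0.40 log units; beyond the scatter). Compound 4 is estimated at 12000 nM, with a range from 3000 nM to 40000 nM.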

Compound 4, half-maximal inhibitory concentration: > 30000 nM
Compound 4: a limit, no number; the forecaster's own chance of this, stated with the estimate: 20%; middle value at least 2.5-fold (0.39 log units) from the limit.
By their numbers in this assay, from the lowest: compounds 1 and 3 (each within the scatter of the next); then compound 2.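

In this assay compound 4 gives > 30000 nM, which is a limit of the assay and not a number. Putting 2,4-dibromophenyl in place of 4-(isobutoxy)phenyl on the amide nitrogen on the short chain therefore gives a number no lower from compound 2 to compound 4 (the limit leaves the size open), and the reading stops here: the limit of > 30000 nM in this assay, at which 1 of the 4 values shown sits. Compound 4 differs from compound 3 only in the chain that joins the sulfur to the amide carbonyl, and compound 3, with the longer chain, gives 1500 nM, so the 2,4-dibromophenyl group does not bring a low number on its own, a point that the near-equal compound 1 and compound 3 could not show.

The compounds shown leave open how the number changes at chain lengths of intermediate size, such as a butanoyl chain in place of the short chain of compound 4. They also leave open whether the long chain tolerates an aryl group with a very different substituent, such as an amine or a carboxylic acid in place of the halogens of compound 1 and compound 3.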